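The source may report more compounds than this note shows. Statements on the series, on what has been measured and on what is new or still open speak of the compounds shown alone.

Measured compounds:
compound 1 `O[C@H](COCCOC[C@@H](O)Cc1cn(Cc2ccc3ccccc3c2)nn1)Cc1ccc(-c2ccccc2)cc1` gives 8600 nM in a functional assay on HCT-116 cells (Homo sapiens) for inhibition, read by MTT assay, with a stated time of 72 h; a lower number here means a stronger inhibitor of growth, a higher number a weaker inhibitor of growth
compound 2 `O=C1COc2ccc(-n3cc(C[C@H](O)COCCOC[C@@H](O)Cc4ccc(-c5ccccc5)cc4)nn3)cc2N1` gives 42500 nM in this assay

Compound 1 holds the lowest of the two numbers in this assay; its nearest neighbour is compound 2, and the step of a 4.9-fold higher number from compound 1 to compound 2 (0.69 log units; beyond the scatter) is beyond the scatter. That step, however, swaps the whole group on the aromatic nitrogen for one containing a six-membered non-aromatic ring with two hetero atoms, and so says little about the change now in question.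

Compound 3 `O[C@H](COCCOC[C@@H](O)Cc1cn(Cc2cccc(-c3ccccc3)c2)nn1)Cc1ccc(-c2ccccc2)cc1` differs from compound 1 by 3-phenylphenyl in place of naphthalen-2-yl on a saturated chain carbon bound to an aromatic nitrogen. Both groups, naphthalen-2-yl and 3-phenylphenyl, are made of two six-membered aromatic rings of carbon only with no hydrogen-bond donors or acceptors. Among the measured compounds shown here, no measured pair shows such a change. For the measured compounds named here, with the pair 1 and 2 as the only comparison, and that one not bearing on it, no step beyond the scatter is expected in this assay from compound 1 to compound 3.

Compound 3 is therefore estimated at 10000 nM, with a range from 3000 nM to 35000 nM; this estimate means a step of a 1.2-fold higher number from compound 1 to compound 3 (0.07 log units; within the scatter).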

Compound 3, concentration for 50% growth inhibition: 7200 nM
The estimate for compound 3 lay 1.4-fold (0.14 log units) above the measured number; low and high end bracket the measured number.
By their numbers in this assay, from the lowest: compounds 3 and 1 (each within the scatter of the next); then compound 2.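

On a saturated chain carbon bound to an aromatic nitrogen, 3-phenylphenyl in place of naphthalen-2-yl gives a 1.2-fold lower number from compound 1 to compound 3 (0.08 log units; within the scatter) in this assay. This pair shows that, for these two groups, both made of two six-membered aromatic rings of carbon only, the exchange leaves the number within the scatter, something the step between compound 1 and compound 2 could not show, since that step also brought in a non-aromatic ring with hetero atoms. No measurement at hand bears on why the two groups read alike.

The compounds shown leave open whether an amine or a carboxylic acid on the 3-phenylphenyl group, or a longer chain between that group and the aromatic nitrogen, would move the number in this assay. Among the compounds shown here, they also leave open whether this result extends beyond this single pair, as only one such exchange at this position can be read, and whether any change elsewhere on the shared core would give a step beyond the scatter.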